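Replacing cyclopentylamino with ethyl(methyl)amino

The source may hold more compounds than are shown below. What is called first, only, known or untested is meant among the compounds shown, and "the series" means these compounds.

In a functional assay on A2780 cells (Homo sapiens) for antiproliferative activity, read by MTT assay, with a stated time of 72 h (a lower number here means a stronger inhibitor, a higher number a weaker inhibitor), compound 1 (`N=C(NC(=N)NC1CCCC1)Nc1ccc(C(F)(F)F)cc1`) gives 2500 nM. Among the compounds with values here, this is the lower of the two numbers available so far. Compound 2 (`CCN(CC)C(=N)NC(=N)Nc1ccc(F)c(F)c1`) gives 20400 nM, and that gap lies beyond the usual scatter, which makes compound 1 the stronger inhibitor of the pair. The two compounds differ in more than one place, so the gap cannot be assigned to any single change.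

Compound 3 (`CCN(C)C(=N)NC(=N)Nc1ccc(C(F)(F)F)cc1`) alters compound 1 in one place: ethyl(methyl)amino in place of cyclopentylamino on a carbon with a double bond to nitrogen. Ethyl(methyl)amino stands in place of cyclopentylamino, on a carbon with a double bond to nitrogen, and the rest of the structure is kept. Within the data shown here, no measured pair isolates this change, so the expectation rests on thin evidence. Compound 2, which also lacks cyclopentylamino, stands at 20400 nM, and this points cautiously towards a weaker result. A moderate rise beyond the scatter is therefore expected in this assay, with an estimated step of a 2.8-fold higher number from compound 1 to compound 3 (0.45 log units; beyond the scatter). The estimate for compound 3 is 7000 nM, with an expected range of 2800 nM to 18000 nM.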

Compound 3, half-maximal inhibitory concentration: 5100 nM
Compound 3: the middle estimate sits 1.4-fold (0.14 log units) above what was measured, within the range that was stated.
By their numbers in this assay, from the lowest: compound 1; then compound 3; then compound 2.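

In this assay, within the data shown here, the pair formed by compound 1 and compound 3 is the first to isolate a single change at this position, and ethyl(methyl)amino in place of cyclopentylamino gives a 2.0-fold higher number from compound 1 to compound 3 (0.31 log units; beyond the scatter), a modest step that lies just beyond the usual scatter. The gap between compound 1 and compound 2 could not be assigned to any one change, whereas this step belongs to this position alone and shows that losing cyclopentylamino weakens the result only modestly, even though the entering group has no ring and no hydrogen-bond donor. Nothing measured here explains the step, and no independent observation bears on its cause.

The ring and the hydrogen-bond donor leave together in this single change, so the pair cannot show which of them, or what combination of the two, accounts for the step. Ethylamino, which keeps a nitrogen-hydrogen bond without a ring, and pyrrolidin-1-yl, which keeps a five-membered ring without that hydrogen, would pull the two apart at this same position on the core of compound 1.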